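This account rests on a few compounds, and the source may have more. Where it says the series, first, only, none or still open, it means among the compounds named here.

Compound 1 `COc1cc(/C=C/C(=O)/C=C/c2cccs2)ccc1OCc1cn(CCOc2cc(=O)oc3ccccc23)nn1`: 12%
Compound 2 `COc1cc(/C=C/C(=O)/C=C/c2cc(OC)c(OC)c(OC)c2)ccc1OCc1cn(CCCCOc2cc(=O)oc3ccccc23)nn1`: 5%

In a functional assay on PC-3 cells (Homo sapiens) for inhibition, read by sulforhodamine B assay, with a stated time of 48 h, tested at 50 uM (a lower number here means less inhibition of growth, a higher number more inhibition of growth at the concentration tested), compound 1 gives 12%, which lies within the usual scatter of compound 2 at 5%. Compound 3 `COc1cc(/C=C/C(=O)/C=C/c2ccccc2)ccc1OCc1cn(CCOc2cc(=O)oc3ccccc23)nn1` is the next to be read against compound 1. The change is phenyl in place of thiophen-2-yl on a double-bonded chain carbon bound to a double-bonded chain carbon. Among the compounds with values here, no measured pair shows what a single change does here, so no step beyond the scatter is expected in this assay, in either direction. The expected change is a number 2 percentage points lower from compound 1 to compound 3 (within the scatter). Compound 3 is estimated at 10%, within an expected range of 2% to 22%.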

Compound 3, percent growth inhibition at one concentration: 10%
Compound 3: middle estimate and measured number agree at the digits printed, and the stated range covers the measured number.
By their numbers in this assay, from the lowest: compounds 2, 3 and 1 (each within the scatter of the next).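

In this assay, phenyl in place of thiophen-2-yl on a double-bonded chain carbon bound to a double-bonded chain carbon gives a number 2 percentage points lower from compound 1 to compound 3 (within the scatter). Within the data shown here, this is the first single-change pair, and it shows that this exchange of aromatic rings, which removes the sulfur, does not move the number beyond the scatter. No evidence is available to explain this result.

The compounds shown leave open whether a ring carrying an amine or a carboxylic acid at this place would behave the same way. They also leave open what a single change elsewhere in the core of compound 1 would do.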